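The source may hold more compounds than are shown below. What is called first, only, known or untested is meant among the compounds shown, and "the series" means these compounds.

In a functional assay on A-431 cells (Homo sapiens) for cytotoxicity, read by MTT assay, with a stated time of 24 h (on this read-out higher numbers stand for weaker inhibition and lower numbers for stronger inhibition), compound 1, `COc1ccc(/C=C\C(=O)O)c(OCc2cn(-c3ccccc3I)nn2)c1CC=C(C)C`, gives 32700 nM, and compound 2, `COc1ccc(/C=C\C(=O)O)c(OCc2cn(-c3ccccc3C#N)nn2)c1CC=C(C)C`, gives 10300 nM. For the measured compounds named here, compound 2 stands at the lowest of the two numbers; the one step measured, a 3.2-fold lower number from compound 1 to compound 2 (0.50 log units; beyond the scatter), is modest and beyond the scatter. Compound 3, `COc1ccc(/C=C\C(=O)O)c(OCc2cn(-c3ccc(NC(C)=O)cc3)nn2)c1CC=C(C)C`, has not been measured in this assay. It differs from compound 2 by 4-acetamidophenyl in place of 2-cyanophenyl on an aromatic nitrogen. Going by the values given here, only the step from compound 1 to compound 2 bears on this change, since both it and the new change alter the group on the aromatic nitrogen of the five-membered ring, and that step was a 3.2-fold lower number from compound 1 to compound 2 (0.50 log units; beyond the scatter). Among the compounds with values here, no measured step exchanges a 2-substituted phenyl for a 4-substituted one, nor brings in an acetamido group, so the direction is not anchored by the data. The two values seen differ by a modest amount, so compound 3 is expected to land near compound 2, with a step of a 1.5-fold higher number from compound 2 to compound 3 (0.16 log units; within the scatter) that may fall within the scatter. Compound 3 is therefore estimated at 15000 nM in this assay, with a range from 4000 nM to 55000 nM.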

Compound 3, half-maximal inhibitory concentration: 23400 nM
Compound 3: middle estimate off by 1.6-fold (0.19 log units), on the low side; the range from low to high includes it.
By their numbers in this assay, from the lowest: compound 2; then compounds 3 and 1 (each within the scatter of the next).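

In this assay the change to 4-acetamidophenyl gives a 2.3-fold higher number from compound 2 to compound 3 (0.36 log units; beyond the scatter), so compound 2 now stands apart from a second partner as well as from the 2-iodophenyl compound. The comparison of the two other groups gives a 1.4-fold lower number from compound 1 to compound 3 (0.15 log units; within the scatter) and does not separate them, even though one carries its substituent as 2-iodophenyl and the other as 4-acetamidophenyl, with an added hydrogen-bond donor. On the aromatic nitrogen, then, only the 2-cyanophenyl group is set apart from the others by steps beyond the scatter, and nothing available here accounts for that difference.

The compounds shown leave open whether the lower number of compound 2 goes with the nitrile itself or with its place on the phenyl ring, a question that a 4-cyanophenyl or a 2-acetamidophenyl group would address directly. They also leave open how an unsubstituted phenyl, or a phenyl bearing an amine or a carboxylic acid, would compare on the same nitrogen.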